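This account rests on a few compounds, and the source may have more. Where it says the series, first, only, none or still open, it means among the compounds named here.

Compound 1 `CN(C)c1cccc(Oc2ccc3c(NCCCNCc4ccco4)ccnc3c2)c1` stands in an ADME assay for permeability, using PAMPA, with a stated time of 30 min, at pH 7.4 (a lower number here means that the compound crosses the layer more slowly, a higher number that the compound crosses the layer faster), at 317 10^-6 cm/s. Within the data shown here, compound 2 `COc1ccc(F)cc1CNCCCNc1ccnc2cc(Oc3cccc(N(C)C)c3)ccc12` gives in this assay a value of 317 10^-6 cm/s, so the two sit level at the digits printed, and the only measured step, no change at the digits printed from compound 1 to compound 2 (within the scatter), stays within the scatter. That exchange is on the chain carbon bound to the amine nitrogen and leaves the rest of the shared core untouched.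

Compound 3 `Fc1ccc(Cc2ccc3c(NCCCNCc4ccco4)ccnc3c2)c(Cl)c1` is not yet measured. It differs from compound 1 in that (2-chloro-4-fluorobenzyl in place of 3-(dimethylamino)phenoxy on an aromatic carbon). Among the measured compounds shown here, no measured step touches this position: the one known step lies at the other end of the shared core and produced no change. Both measured values already sit high in this assay, and nothing in the series points toward a direction for the new change. The expected step is therefore a 1.1-fold lower number from compound 1 to compound 3 (0.02 log units; within the scatter), none beyond the scatter. Compound 3 is thus estimated at 300 10^-6 cm/s, with a range from 150 10^-6 cm/s to 500 10^-6 cm/s.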

Compound 3, apparent permeability: 23 10^-6 cm/s
Compound 3: middle estimate off by 13-fold (1.12 log units), on the high side; measured number outside the range, below it.
By their numbers in this assay, from the lowest: compound 3; then compounds 1 and 2 (each within the scatter of the next).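

In this assay the aromatic carbon meta to a fused ring and para to a fused ring proves far more sensitive than the chain end, whose only earlier step stayed within the scatter: 2-chloro-4-fluorobenzyl in place of 3-(dimethylamino)phenoxy gives a 14-fold lower number from compound 1 to compound 3 (1.14 log units; beyond the scatter). Both groups hold one six-membered aromatic ring of carbon only and have similar size, with 10 heavy atoms leaving and 9 entering, yet the hydrogen-bond acceptors go from 2 to 0 and the nitrogen and oxygen give way to fluorine and chlorine, so a change of ring count cannot be what separates this pair. Nothing available here bears on what lies behind this step.

The exchange alters the link to the shared core and the substituents on the ring at once, so the compounds shown do not assign the step to either; a 3-(dimethylamino)benzyl or a 2-chloro-4-fluorophenoxy group at this carbon would separate the two. On these data alone, it also remains open whether a change here has the same size with 5-fluoro-2-methoxyphenyl in place of furan-2-yl on the chain.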